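Thiophene to methylthiazole on the shared core

The compounds below may be only part of what the source reports. "The series", "measured", "known", "first", "only" and "open" are said of these compounds alone.

Compound 3 `c1ccc(-c2ccsc2)c(OCC2=NCCN2)c1` is the only one of the three measured compounds to give a number in a functional assay for activation of Alpha-1B adrenergic receptor (Homo sapiens), read by calcium flux (on this read-out higher numbers stand for an effect only at larger amounts of compound and lower numbers for an effect already at smaller amounts), where compound 3 gives 15.9 nM. Compound 1 `c1ccc(-c2ccncc2)c(OCC2=NCCN2)c1` reaches only a limit of this assay, < 100000 nM. Compound 2 `c1cnc(-c2ccccc2OCC2=NCCN2)nc1` likewise gives only a limit, < 100000 nM. Both of those values sit at the limit of < 100000 nM in this assay, at which 2 of the 3 values shown sit. The steps a step that the limit leaves unreadable from compound 1 to compound 3 and a step that the limit leaves unreadable from compound 2 to compound 3 alter the same ring as the change now considered, yet neither can be read, and a step that the two limits leave unreadable from compound 1 to compound 2 is equally unreadable. Compound 4 `Cc1csc(-c2ccccc2OCC2=NCCN2)n1` differs from compound 3 by 4-methyl-1,3-thiazol-2-yl in place of thiophen-3-yl on an aromatic carbon. Among the compounds with values here, no measured step gives a readable size for such a change. The expected step is a 6.3-fold higher number from compound 3 to compound 4 (0.80 log units; beyond the scatter). Compound 4 is estimated at 100 nM, with a range from 10 nM to 1500 nM.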

Compound 4, half-maximal effective concentration: < 100000 nM
Compound 4: no number, only a limit; the forecaster's own chance of this, stated with the estimate: 10%; the middle value is on the limit's open side.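

In this assay compound 4 gives only a limit, and no step to compound 4 from compound 1, compound 2 or compound 3 can be read: the limit of < 100000 nM in this assay, at which 3 of the 4 values shown sit.

The compounds shown leave open the size of the change from thiophen-3-yl to 4-methyl-1,3-thiazol-2-yl.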